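From a Limit to a Number at the Sulfur

This account rests on a few compounds, and the source may have more. Where it says the series, first, only, none or still open, it means among the compounds named here.

In a functional assay on DU-145 cells (Homo sapiens) for inhibition, read by trypan blue exclusion, with a stated time of 96 h (on this read-out lower numbers stand for stronger inhibition of growth and higher numbers for weaker inhibition of growth), compound 1 (`O=C(/C(=C\c1ccc(Br)cc1)SCc1ccc(Cl)cc1)c1ccc(Cl)cc1`) gives 1000 nM as a true number. Compound 2 (`CN(C)c1ccc(/C=C(/Sc2ccc(Br)cc2)C(=O)c2ccc(Cl)cc2)cc1`) gives > 100000 nM as its reading, and that is a limit of the assay and not a number.

Compound 3 (`CN(C)c1ccc(/C=C(/SCc2ccc(Cl)cc2)C(=O)c2ccc(Cl)cc2)cc1`) has not yet been measured. It differs from compound 2 in one place, with 4-chlorobenzyl in place of 4-bromophenyl on a sulfur.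

For the measured compounds named here, no measured pair shows this swap on its own, so any expectation here is loose. Going by the values given here, the only guide is compound 1, which carries the same 4-chlorobenzyl on its sulfur and gives 1000 nM in this assay as its reading. On that basis the change is expected to shift the reading toward stronger inhibition of growth, and by clearly more than the usual scatter. The estimated shift is an at least 33-fold lower number from compound 2 to compound 3 (1.52 log units; beyond the scatter) in size. For compound 3 the expected value is 3000 nM with an estimated range from 500 nM to 30000 nM in this assay when it is measured.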

Compound 3, concentration for 50% growth inhibition: > 100000 nM
Compound 3 gave a limit, no number; the forecaster's own chance of this, stated with the estimate: 15%; at least 33-fold (1.52 log units) between middle value and limit.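

Replacing 4-bromophenyl with 4-chlorobenzyl on the sulfur does not, on its own, bring a measurable reading in this assay while the dimethylamino group stays in place. The step between these two compounds cannot be read, because neither reading is a true number and both rest on the same assay limit: the limit of > 100000 nM in this assay, at which 2 of the 3 values shown sit.

For the compounds shown here, with 4-chlorobenzyl held on the sulfur, dimethylamino in place of bromo on an aromatic carbon gives an at least 100-fold higher number from compound 1 to compound 3 (2.00 log units; beyond the scatter), a large step beyond the scatter, so this change, which the earlier compounds could not show alone, goes with a clear weakening of growth inhibition.

The compounds shown leave open whether 4-bromophenyl on the sulfur would give a true number with bromo on the aromatic carbon, and how far past its limit the real reading of compound 3 lies. They also leave open whether a plain amino group or a methoxy group in place of dimethylamino would keep the growth inhibition seen with bromo.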